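A 2-ethylphenyl swap on the shared core

This account rests on a few compounds, and the source may have more. Where it says the series, first, only, none or still open, it means among the compounds named here.

Compound 1 `Cc1c(-n2cc(COc3ccc(/C=C/C(=O)c4cc5c(cc4O)OC(C)(C)CC5)cc3)nn2)cccc1[N+](=O)[O-]`: 65900 nM
Compound 2 `CC(=O)c1ccc(-n2cc(COc3ccc(/C=C/C(=O)c4cc5c(cc4O)OC(C)(C)CC5)cc3)nn2)cc1`: 66300 nM

In a functional assay on A549 cells (Homo sapiens) for antiproliferative activity, read by MTT assay (on this read-out lower numbers stand for stronger inhibition and higher numbers for weaker inhibition), compound 2 gives 66300 nM, level with compound 1 within the scatter. Compound 3 `CCc1ccccc1-n1cc(COc2ccc(/C=C/C(=O)c3cc4c(cc3O)OC(C)(C)CC4)cc2)nn1` keeps the shared core and differs from compound 2 at one place: 2-ethylphenyl in place of 4-acetylphenyl on an aromatic nitrogen. In words, 2-ethylphenyl stands in place of 4-acetylphenyl on an aromatic nitrogen. Within the data shown here, only one measured step bears on this place, a 1.0-fold higher number from compound 1 to compound 2 (0.00 log units; within the scatter), and it exchanged one substituted phenyl for another. No change beyond the scatter is therefore expected. The estimated step is a 1.1-fold lower number from compound 2 to compound 3 (0.04 log units; within the scatter). Compound 3 is expected at 60000 nM, within an estimated range of 25000 nM to 120000 nM.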

Compound 3, half-maximal inhibitory concentration: 137000 nM
Estimate against measurement, compound 3: 2.3-fold (0.36 log units) below, outside the stated range (above it).
By their numbers in this assay, from the lowest: compounds 1 and 2 (each within the scatter of the next); then compound 3.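

In this assay the group on the aromatic nitrogen now makes a difference: 2-ethylphenyl gives a 2.1-fold higher number from compound 2 to compound 3 (0.32 log units; beyond the scatter) and a 2.1-fold higher number from compound 1 to compound 3 (0.32 log units; beyond the scatter) in the same comparison, each step modest but beyond the scatter. Compounds 1 and 2 alone had shown no change at this place, so not every exchange of one substituted phenyl for another is silent here. Nothing shown accounts for the step.

Going by these compounds, it remains open whether an unsubstituted phenyl would stand with compound 3 or with compounds 1 and 2. On these data alone, it also remains open how an amine, a carboxylic acid or a longer chain on that nitrogen would read.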